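The compounds below may be only part of what the source reports. "The series", "measured", "known", "first", "only" and "open" are said of these compounds alone.

Measured compounds in an in vivo ADME assay on the whole organism for pharmacokinetics, with Rattus norvegicus as the target, at a dose of 0.5 mg/kg by the intravenous route; a lower number here means slower removal, a higher number faster removal of the compound:

- compound 1, `Cc1nc(N)nc(-c2c(Nc3ccn(C)n3)nc3ccc(-c4cncnc4)cn23)n1`: 41.7 mL/min/kg
- compound 2, `CC(=O)Nc1cc(-c2c(Nc3cc[nH]n3)nc3cccnn23)nc(C)n1`: 43.3 mL/min/kg

Of the compounds shown here, two have been run in this assay so far. Compound 1 gives 41.7 mL/min/kg there, and compound 2 gives 43.3 mL/min/kg. These two numbers sit within the usual scatter of each other, so neither compound stands apart from the other on clearance.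

The next compound, compound 3, `Cc1nccc(-c2c(Nc3cc[nH]n3)nc3cccnn23)n1`, is built from compound 2 by a single change: hydrogen in place of acetamido on an aromatic carbon. Among the compounds with values here, no measured pair shows what this kind of change does in this assay, so the expectation rests on compound 2 alone, with no direction favoured beyond the scatter. The step from compound 2 to compound 3 is expected to be about a 1.0-fold higher number from compound 2 to compound 3 (0.02 log units; within the scatter). Compound 3 is therefore estimated at 45 mL/min/kg in this assay, in a range from 22 mL/min/kg to 85 mL/min/kg.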

Compound 3, clearance: 31.7 mL/min/kg
Compound 3: the middle estimate sits 1.4-fold (0.15 log units) above what was measured; low and high end bracket the measured number.
By their numbers in this assay, from the lowest: compounds 3, 1 and 2 (each within the scatter of the next).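

Replacing acetamido with hydrogen on this aromatic carbon, next to the ring nitrogen of a six-membered aromatic ring with 2 nitrogen, gives a 1.4-fold lower number from compound 2 to compound 3 (0.14 log units; within the scatter) in this assay. Within the data shown here, this is the first matched pair at this position, and it shows that clearance in the rat stays within the usual scatter whether the position carries the acetamido group or only hydrogen. Nothing measured here bears on why the two compounds read so alike.

A single pair on one core cannot show whether other groups at this position, such as a methoxy group, a chlorine atom or a longer amide chain, would stay within the scatter as well. It also leaves open whether the same change would read alike on the core of compound 1.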